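Working notes: the step from compound 3 to compound 4

A few compounds are considered here, and "the series" means these few. Any claim that something is new, unique, unknown or untested is made for them only; others in the source may bear on it.

Values measured in an ADME assay on L6 cells (Rattus norvegicus) for cytotoxicity, read by resazurin assay, with a stated time of 72 h (on this read-out lower numbers stand for stronger inhibition and higher numbers for weaker inhibition), so far
compound 1 `COc1cccc(C(O)(c2ccc(Cl)cc2)c2cccnc2)c1` gives 85600 nM
compound 2 `CC(C)Oc1ccc(C(O)(c2ccc(C(F)(F)F)cc2)c2cccnc2)cc1` gives 47600 nM
compound 3 `N#Cc1ccc(C(O)(c2ccc(C(F)(F)F)cc2)c2cccnc2)c(F)c1` gives 56100 nM

Compound 3 at 56100 nM is the middle of the three numbers and lies within the usual scatter of both compound 1 and compound 2. For the measured compounds named here, no measured pair differs in one place only, so the series offers no direct step. Compound 4 `CC(C)c1ccc(C(O)(c2ccc(C(F)(F)F)cc2)c2cccnc2)cc1` remains to be measured. The change 4-isopropylphenyl in place of 4-cyano-2-fluorophenyl on a saturated chain carbon bound to two aromatic carbons and an oxygen on a saturated carbon puts 4-isopropylphenyl in place of 4-cyano-2-fluorophenyl on a saturated chain carbon bound to two aromatic carbons and an oxygen on a saturated carbon. In this assay no step beyond the scatter is expected, with a slight lean towards a lower number. The expected change is a 1.4-fold lower number from compound 3 to compound 4 (0.15 log units; within the scatter) and it stays an estimate. Compound 4 is estimated at 40000 nM with an expected range from 18000 nM to 80000 nM in this read-out.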

Compound 4, half-maximal inhibitory concentration: 56300 nM
Beside the measured number, compound 4's estimate is 1.4-fold (0.15 log units) below it, within the range that was stated.
By their numbers in this assay, from the lowest: compounds 2, 3, 4 and 1 (each within the scatter of the next).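

In this assay, 4-isopropylphenyl in place of 4-cyano-2-fluorophenyl on the saturated chain carbon gives a 1.0-fold higher number from compound 3 to compound 4 (0.00 log units; within the scatter), so this change of the whole group leaves the number within the scatter. Isopropyl in place of isopropoxy on an aromatic carbon gives a 1.2-fold higher number from compound 2 to compound 4 (0.07 log units; within the scatter), and this smaller change also stays within the scatter. No available evidence bears on these two steps.

From the compounds shown here alone, whether a carboxylic acid or an amine in place of isopropyl on that aromatic carbon would give a step beyond the scatter remains open. The same question stands for a longer chain there.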